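Trading a nitrophenyl for a short propyl chain

The source may hold more compounds than are shown below. What is called first, only, known or untested is meant among the compounds shown, and "the series" means these compounds.

Of the compounds shown here, three have been measured in an assay on isolated protein for inhibition of aldehyde dehydrogenase 1A1 (Homo sapiens), read by spectrophotometry, tested at 10 uM; a lower number here means less inhibition, a higher number more inhibition at the concentration tested (going by the name of the read-out). Compound 1, with the structure `Cc1cccc(Cn2c(CN3CCN(C(=O)c4ccc([N+](=O)[O-])cc4)CC3)nc3ccccc32)c1`, gives 24.3% in this assay, the lowest of the three numbers. Compound 2, `O=C(C1CC1)N1CCN(Cc2nc3ccccc3n2Cc2ccccc2F)CC1`, gives 40.7%, a number higher than that of compound 1 by more than the usual scatter. Compound 3, `Cc1cccc(Cn2c(OC3CCN(C(=O)C4CC4)CC3)nc3ccccc32)c1`, gives 80.6%, the highest of the three and again clearly above compound 1.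

Compound 4, `CCCC(=O)N1CCN(Cc2nc3ccccc3n2Cc2cccc(C)c2)CC1`, has not been measured. It differs from compound 1 in one place:

propyl in place of 4-nitrophenyl on a carbonyl carbon

For the measured compounds named here, with no measured pair showing this exact change, the expectation rests on the other compounds. Compound 2 also carries a small, ring-free-or-nearly-so carbonyl group in the same kind of position and gives 40.7%, so a step upward from compound 1 is expected, modest in size. The expected step is a number 15.7 percentage points higher from compound 1 to compound 4 (beyond the scatter) in this assay. Compound 4 is therefore estimated at 40% in this assay, within a range from 20% to 62%.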

Compound 4, a percentage reported as inhibition, at one concentration (the size of the read-out at that concentration, not a potency): 79.1%
Estimate against measurement, compound 4: 39.1 percentage points below; measured number outside the range, above it.
By their numbers in this assay, from the lowest: compound 1; then compound 2; then compounds 4 and 3 (each within the scatter of the next).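

In this assay, replacing 4-nitrophenyl with propyl on this carbonyl carbon gives a large step: a number 54.8 percentage points higher from compound 1 to compound 4 (beyond the scatter). The rest of the structure is unchanged, so the step belongs to this one place, and the group here can by itself change the read-out substantially. An aromatic ring is not needed on this carbonyl carbon for a high reading, although nothing available explains why the number moves so far.

A plain phenyl on the same carbonyl carbon would help separate the part played by the ring from that of the nitro group, and the compounds shown leave that question open. They also leave open how a longer chain such as hexyl, or a propyl chain ending in an amine, would read at this place.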